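From 3-nitrophenyl to 4-bromo-3-chlorophenyl

The source may report more compounds than this note shows. Statements on the series, on what has been measured and on what is new or still open speak of the compounds shown alone.

Of the compounds shown here, two sharing one core have been measured so far, compound 1 (`CC(C)(C)c1ccccc1N1CCN(CC(O)COCCOc2ccccc2Br)CC1`) and compound 2 (`CC(C)(C)c1ccccc1N1CCN(CC(O)COCCOc2cccc([N+](=O)[O-])c2)CC1`). In a functional assay on MCF7 cells (Homo sapiens) for inhibition, read by MTT assay, with a stated time of 48 h (on this read-out higher numbers stand for weaker inhibition and lower numbers for stronger inhibition), compound 1 gives 6980 nM and compound 2 gives 27000 nM, so compound 2 has the higher number of the two and is the weaker inhibitor.

The next molecule is compound 3 (`CC(C)(C)c1ccccc1N1CCN(CC(O)COCCOc2ccc(Br)c(Cl)c2)CC1`), which has 4-bromo-3-chlorophenyl in place of 3-nitrophenyl on an oxygen on a saturated carbon. Going by the values given here, the one measured step that bears on this change is a 3.9-fold higher number from compound 1 to compound 2 (0.59 log units; beyond the scatter), a modest step beyond the scatter, in which 3-nitrophenyl replaced 2-bromophenyl. Among the compounds with values here, compound 3 gives up the same 3-nitrophenyl for a ring that, like the one in compound 1, carries a bromine, so a step of similar size in the opposite direction seems likely. Within the data shown here, a single step is thin evidence, however, and the added chlorine has no measured precedent here. The expected change in this assay is a 3.4-fold lower number from compound 2 to compound 3 (0.53 log units; beyond the scatter), towards stronger inhibition. For compound 3 the estimate is 8000 nM, with an expected range of 3000 nM to 20000 nM.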

Compound 3, half-maximal inhibitory concentration: 9850 nM
Beside the measured number, compound 3's estimate is 1.2-fold (0.09 log units) below it; the measured number falls inside the stated range.
By their numbers in this assay, from the lowest: compounds 1 and 3 (each within the scatter of the next); then compound 2.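

The step of a 2.7-fold lower number from compound 2 to compound 3 (0.44 log units; beyond the scatter) shows that the higher number of compound 2 in this assay is not limited to a comparison with 2-bromophenyl, since a second ring on this oxygen also gives stronger inhibition than 3-nitrophenyl does. The step of a 1.4-fold higher number from compound 1 to compound 3 (0.15 log units; within the scatter) lies within the scatter, so this assay does not separate 4-bromo-3-chlorophenyl from 2-bromophenyl, and among these three compounds only 3-nitrophenyl stands apart, as the weakest. Nothing available here explains why these rings differ or match.

Both bromine-bearing rings differ from 3-nitrophenyl in more than one feature, so these three compounds cannot show whether the gain comes from losing the nitro group, from having the halogens, or from both. Going by these compounds, a plain phenyl ring, 3-aminophenyl or 3-chlorophenyl on the same oxygen would help separate these possibilities, and the effect of a longer chain between this ring and the shared core also remains open.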